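Swapping the indole nitrogen substituent in a 5-alpha-reductase series

A few compounds are considered here, and "the series" means these few. Any claim that something is new, unique, unknown or untested is made for them only; others in the source may bear on it.

Measured compounds:
compound 1 `CCC(C)n1ccc2cc(/C(C)=C/C(=O)Nc3ccccc3OCCCC(=O)O)ccc21` 67 nM
compound 2 `CCCCC(CC)n1ccc2cc(/C(C)=C/C(=O)Nc3ccccc3OCCCC(=O)O)ccc21` 7.1 nM

The two measured compounds differ only at the group on the aromatic nitrogen. In an assay on Prostate gland for inhibition of steroid 5-alpha-reductase (Rattus norvegicus) (on this read-out higher numbers stand for weaker inhibition and lower numbers for stronger inhibition), compound 1 gives 67 nM, while compound 2 gives 7.1 nM, the lowest of the two numbers, and the step of a 9.4-fold lower number from compound 1 to compound 2 (0.97 log units; beyond the scatter) lies beyond the scatter. Compound 3 `C/C(=C\C(=O)Nc1ccccc1OCCCC(=O)O)c1ccc2c(ccn2Cc2ccc(F)cc2)c1` has not yet been measured. Its change from compound 2 is 4-fluorobenzyl in place of 1-ethylpentyl on an aromatic nitrogen. For the measured compounds named here, the only measured step, from compound 1 to compound 2, shows that enlarging the group on that nitrogen with a propyl lowered the number markedly, so a group of comparable size is not expected to lose much; no measured step, however, tests a 4-fluorobenzyl in that place, and whether an aromatic ring there behaves like the chain is unknown. The expectation is therefore a step of a 1.4-fold higher number from compound 2 to compound 3 (0.15 log units; within the scatter), within or near the scatter. Compound 3 is estimated at 10 nM, with a range from 3 nM to 40 nM.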

Compound 3, half-maximal inhibitory concentration: 97 nM
For compound 3 the middle estimate is 9.7-fold (0.99 log units) below the measured one; the measured number lies above the stated range.
By their numbers in this assay, from the lowest: compound 2; then compounds 1 and 3 (each within the scatter of the next).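

In this assay, 4-fluorobenzyl in place of 1-ethylpentyl gives a 14-fold higher number from compound 2 to compound 3 (1.14 log units; beyond the scatter), although the two groups are close in heavy-atom count, so the number at this position does not follow group size alone, which compound 1 and compound 2 could not show. Set against the smaller sec-butyl, 4-fluorobenzyl gives a 1.4-fold higher number from compound 1 to compound 3 (0.16 log units; within the scatter), leaving the low number of compound 2 unique to 1-ethylpentyl among the three groups shown on this aromatic nitrogen. No measurement given here explains why the aromatic group departs from the branched chain.

The compounds shown leave open whether the higher number goes with the aromatic ring, the fluorine or the single carbon that joins the ring to the nitrogen, and a plain benzyl or a cyclohexylmethyl on the same nitrogen would help to separate these. They also leave open how far the gain with 1-ethylpentyl extends, since neither a longer branched chain such as 1-propylhexyl nor an unbranched chain such as n-heptyl appears among them.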